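Compound 3: trifluoromethyl in place of nitro

This account rests on a few compounds, and the source may have more. Where it says the series, first, only, none or still open, it means among the compounds named here.

Compound 1 `CS(=O)(=O)N1C(=O)COC12C=CC(=O)C=C2`: > 10000 nM, a limit
Compound 2 `O=C1C=CC2(C=C1)OCC(=O)N2S(=O)(=O)c1ccc([N+](=O)[O-])cc1`: > 10000 nM, a limit

Both entries come from a functional assay on MDA-MB-231 cells (Homo sapiens) for inhibition, read by sulforhodamine B assay, with a stated time of 74 h; a higher number here means a weaker inhibitor, a lower number a stronger inhibitor. Compound 2 gives > 10000 nM, which is a limit and not a number. It therefore stands at the limit of > 10000 nM in this assay, at which 2 of the 2 values shown sit, and no measured value yet exists in the series.

Compound 3 `O=C1C=CC2(C=C1)OCC(=O)N2S(=O)(=O)c1ccc(C(F)(F)F)cc1` has trifluoromethyl in place of nitro on an aromatic carbon, para to a large group: trifluoromethyl in place of nitro on an aromatic carbon. Within the data shown here, no measured step is available to size this change. The expected step is a number no higher from compound 2 to compound 3 (the limit leaves the size open), and no shift beyond the scatter is expected in this assay. From the compounds shown here alone, the direction remains open, and a further limit is the more likely report. For compound 3 the estimated value is 10000 nM, with an expected range from 3000 nM to 30000 nM.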

Compound 3, half-maximal inhibitory concentration: 2100 nM
Estimate against measurement, compound 3: 4.8-fold (0.68 log units) above; the whole stated range lies above it.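

In this assay, among these compounds, compound 3 gives 2100 nM as the first true number, so this aromatic carbon, para to a large group, is a place where a single change can yield a measured number. Trifluoromethyl in place of nitro gives an at least 4.7-fold lower number from compound 2 to compound 3 (0.67 log units; beyond the scatter) at this position. The full size of that step cannot be read because compound 2 carries a limit and not a number: the limit of > 10000 nM in this assay, at which 2 of the 3 values shown sit.

Among the compounds shown here, whether the gain is particular to trifluoromethyl remains open, since only two groups are compared at this position and a chlorine atom, a methoxy group or an amine would be needed to test it. Also open, from the compounds shown here alone, is how a carboxylic acid at the same carbon would read in this assay and whether any such change would lower the number further.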